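A few compounds are considered here, and "the series" means these few. Any claim that something is new, unique, unknown or untested is made for them only; others in the source may bear on it.

This piece follows a series of compounds tested in a functional assay on CHO-K1 cells for antagonist activity at transient receptor potential cation channel subfamily V member 1 (Homo sapiens), read by FLIPR; on this read-out lower numbers stand for stronger inhibition and higher numbers for weaker inhibition. Going by the values given here, compound 1 `CC(C(=O)NCc1ccc(C(F)(F)F)nc1N(C)c1ccccc1)c1ccc(NS(C)(=O)=O)c(F)c1` gives 0.9 nM in this assay, the lowest of the two numbers measured so far. Compound 2 `CC(C(=O)NCc1ccc(C(F)(F)F)nc1N1CCC(OC(=O)C(C)(C)C)CC1)c1ccc(NS(C)(=O)=O)c(F)c1` gives 2 nM in this assay, a higher number than compound 1 by a gap that lies beyond the usual scatter, so compound 1 stands as the stronger inhibitor of the two. Among the compounds with values here, no single step between these two compounds is recorded, so only their two values can be set side by side.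

Compound 3 `CC(C(=O)NCc1ccc(C(F)(F)F)nc1N1CCN(C)CC1)c1ccc(NS(C)(=O)=O)c(F)c1` has not yet been measured. It differs from compound 1 in one place: 4-methylpiperazin-1-yl in place of methyl(phenyl)amino on an aromatic carbon. The group that leaves carries one six-membered aromatic ring of carbon only; the group that enters carries one six-membered non-aromatic ring with 2 hetero atoms.

In this assay the step from compound 1 to compound 3 is expected to be a 5.6-fold higher number from compound 1 to compound 3 (0.74 log units; beyond the scatter), a moderate weakening that slightly exceeds the scatter. Compound 3 is therefore estimated to give about 5 nM, with a likely range from 1.5 nM to 20 nM.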

Compound 3, inhibition constant: 146 nM
Estimate against measurement, compound 3: 29-fold (1.47 log units) below; measured number above the stated range.
By their numbers in this assay, from the lowest: compound 1; then compound 2; then compound 3.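

In this assay this position on the shared core proves highly sensitive to what it carries: 4-methylpiperazin-1-yl in place of methyl(phenyl)amino on the aromatic carbon next to the ring nitrogen brings a large loss of inhibition (a 160-fold higher number from compound 1 to compound 3 (2.21 log units; beyond the scatter)). The size of the step does not follow the simple counts, since the two groups are close in heavy atoms, neither has a hydrogen-bond donor, and neither carries a net charge; what differs is that a six-membered aromatic ring of carbon only gives way to a six-membered non-aromatic ring with a second nitrogen. Nothing measured here explains why this change costs so much.

The compounds shown leave open which part of the change accounts for the step: the loss of the aromatic ring, or the arrival of the second nitrogen with its methyl group. A piperidin-1-yl or morpholin-4-yl group on the same carbon, or a phenyl ring joined through the same methylamino link but carrying a dimethylamino group, would help to pull these two parts apart.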